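A few compounds are considered here, and "the series" means these few. Any claim that something is new, unique, unknown or untested is made for them only; others in the source may bear on it.

Of the compounds shown here, three have been tested in an assay on HEK293 cells for antagonist activity at Nicotinic acetylcholine receptor alpha-4/beta-2 (Mus musculus), read by FLIPR, using a membrane potential dye; on this read-out higher numbers stand for weaker inhibition and lower numbers for stronger inhibition. Compound 1 `CN1CC[C@@H]2CC[C@H](OCc3ccccc3)C[C@@H]21` carries a phenyl group on its ether chain. In this assay compound 1 gives no number but a limit of the assay, > 300000 nM. Compound 2 `COCCO[C@H]1CC[C@H]2CCN(C)[C@H]2C1` differs from compound 1 in one place: methoxymethyl in place of phenyl on a saturated chain carbon bound to an oxygen on a saturated carbon. In this assay compound 2 also reaches only a limit, > 300000 nM. The step that the two limits leave unreadable from compound 1 to compound 2 therefore cannot be read. Compound 3 `CN1CCC2=CC[C@H](OCc3ccccc3)C[C@@H]21` has another core than compound 1, and the difference between the two cores is not broken down here. In this assay compound 3 likewise stops at a limit, > 300000 nM. Compound 4 `COCCO[C@H]1CC=C2CCN(C)[C@H]2C1` stands to compound 3 as compound 2 stands to compound 1: methoxymethyl in place of phenyl on a saturated chain carbon bound to an oxygen on a saturated carbon, with the place described in the same words, so it is the same change carried onto a second core. All that is known about this change so far is the limit of > 300000 nM in this assay, at which 3 of the 3 values shown sit. Because the limit of > 300000 nM in this assay, at which 3 of the 3 values shown sit, holds for both compound 1 and compound 2 across this very change, compound 4 is expected to stay at the limit too, the expected step being a step that the limit leaves unreadable from compound 3 to compound 4. The estimate for compound 4 in this assay is 400000 nM, between 100000 nM and 1500000 nM.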

Compound 4, half-maximal inhibitory concentration: > 300000 nM
Compound 4: a limit, no number; the forecaster's own chance of this, stated with the estimate: 85%; the middle value lies beyond the limit too.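

No step can be read from compound 3 to compound 4 or from compound 1 to compound 2 in this assay, as each of these compounds gives only a limit and no number: the limit of > 300000 nM in this assay, at which 4 of the 4 values shown sit. The compounds shown leave open how much swapping phenyl for methoxymethyl changes inhibition on either core, and whether any of them inhibits this receptor measurably.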